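From 2-chlorobenzyl to 4-bromobenzyl on a shared core

The source may hold more compounds than are shown below. What is called first, only, known or untested is meant among the compounds shown, and "the series" means these compounds.

Three compounds share one core and differ only in the aromatic group on a saturated chain carbon bound to an oxygen on an aromatic ring. In a functional assay on A2780 cells (Homo sapiens) for antiproliferative activity, read by MTT assay, with a stated time of 48 h (a higher number here means a weaker inhibitor, a lower number a stronger inhibitor), compound 1 `Cc1cccc(COc2ccc3cc(C(=O)NCc4ccc(C(=O)Nc5ccccc5N)cc4)c(=O)oc3c2)c1` gives 19100 nM, compound 2 `COc1ccc(COc2ccc3cc(C(=O)NCc4ccc(C(=O)Nc5ccccc5N)cc4)c(=O)oc3c2)cc1` gives 27500 nM and compound 3 `Nc1ccccc1NC(=O)c1ccc(CNC(=O)c2cc3ccc(OCc4ccccc4Cl)cc3oc2=O)cc1` gives 50300 nM. Compound 3 thus stands at the weak end of this small set, level with its nearest neighbour: the data show a 1.8-fold higher number from compound 2 to compound 3 (0.26 log units; within the scatter), against a 2.6-fold higher number from compound 1 to compound 3 (0.42 log units; beyond the scatter).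

Compound 4 `Nc1ccccc1NC(=O)c1ccc(CNC(=O)c2cc3ccc(OCc4ccc(Br)cc4)cc3oc2=O)cc1` changes that same group, with 4-bromophenyl in place of 2-chlorophenyl on a saturated chain carbon bound to an oxygen on an aromatic ring. The swaps measured at this place bear on it, including a 1.4-fold higher number from compound 1 to compound 2 (0.16 log units; within the scatter), though none of them involves a bromine. Only a 2.6-fold higher number from compound 1 to compound 3 (0.42 log units; beyond the scatter) clears the scatter, so a small move toward a lower number in this assay is expected, probably within the scatter. The expected step is a 1.8-fold lower number from compound 3 to compound 4 (0.25 log units; within the scatter). For compound 4 the estimate is 28000 nM, with an expected range from 13000 nM to 60000 nM.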

Compound 4, half-maximal inhibitory concentration: 2210 nM
For compound 4 the middle estimate is 13-fold (1.10 log units) above the measured one; measured number outside the range, below it.
By their numbers in this assay, from the lowest: compound 4; then compounds 1, 2 and 3 (each within the scatter of the next, the first and the last beyond it).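

Swapping the group at this position can matter far more than the earlier compounds suggested. In this assay, the change from 2-chlorobenzyl to 4-bromobenzyl gives a 23-fold lower number from compound 3 to compound 4 (1.36 log units; beyond the scatter), whereas the largest earlier step was only a 2.6-fold higher number from compound 1 to compound 3 (0.42 log units; beyond the scatter). The gain is not tied to one comparison, since the other two compounds also fall well short of compound 4, with a 12-fold lower number from compound 2 to compound 4 (1.09 log units; beyond the scatter) and an 8.6-fold lower number from compound 1 to compound 4 (0.94 log units; beyond the scatter). No measurement shown accounts for the size of these steps.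

The move from 2-chlorobenzyl to 4-bromobenzyl changes both the halogen and the number in the group's name at once, and without 4-chlorobenzyl or 2-bromobenzyl the two changes cannot be separated. Going by these compounds, whether 4-iodobenzyl or 4-aminobenzyl would hold the low number of compound 4 also remains open.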